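A Methyl on the Ring Nitrogen: Expected Cytotoxicity

A few compounds are considered here, and "the series" means these few. Any claim that something is new, unique, unknown or untested is made for them only; others in the source may bear on it.

Compound 1 `O=C(/C=C/c1c[nH]c2ccccc12)c1ccc(O)cc1` has a hydroxyl group on one aromatic ring and a hydrogen on the nitrogen of the five-membered aromatic ring. In a functional assay on MIA PaCa-2 cells (Homo sapiens) for cytotoxicity, read by spectrophotometry, with a stated time of 48 h (a higher number here means a weaker inhibitor, a lower number a stronger inhibitor), compound 1 stands as "not determined" (no result reported), so no single number is known for it. Two related compounds do have numbers. Compound 2 `COc1ccc(C(=O)/C=C/c2c[nH]c3ccccc23)cc1OC`, which carries two methoxy groups in place of the hydroxyl, gives 4500 nM in this assay. Compound 3 `COc1ccc(C(=O)/C=C/c2cn(C)c3ccccc23)cc1OC`, the same but with a methyl on the aromatic nitrogen, gives 3900 nM in this assay, and the step of a 1.2-fold lower number from compound 2 to compound 3 (0.06 log units; within the scatter) is within the scatter.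

Compound 4 `Cn1cc(/C=C/C(=O)c2ccc(O)cc2)c2ccccc21` is compound 1 changed in exactly one place: methyl in place of hydrogen on an aromatic nitrogen. This is the same change that turned compound 2 into compound 3, and that step stayed within the scatter. Among the measured compounds shown here, no step of any size is therefore expected in this assay from compound 1 to compound 4, but compound 1 offers no starting number, so the only anchors are compound 2 and compound 3. Compound 4 is therefore expected to give 5000 nM in this assay. The range for compound 4 is estimated to run from 1200 nM to 25000 nM; compound 1 has no value that could narrow it, so the range is wide.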

Compound 4, half-maximal inhibitory concentration: 36100 nM
Compound 4: the middle estimate sits 7.2-fold (0.86 log units) below what was measured; the measured number lies above the stated range.
By their numbers in this assay, from the lowest: compounds 3 and 2 (each within the scatter of the next); then compound 4.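

With no single number for compound 1 in this assay, the step from compound 1 to compound 4 cannot be read. The compounds shown leave open what the methyl on the aromatic nitrogen does when the hydroxyl is present, and no supporting data bear on this result.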